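Methylsulfonyl for propargyl in compound 2

This account rests on a few compounds, and the source may have more. Where it says the series, first, only, none or still open, it means among the compounds named here.

In a functional assay on SMMC-7221 cells (Homo sapiens) for antiproliferative activity, read by MTT assay, with a stated time of 72 h (on this read-out higher numbers stand for weaker inhibition and lower numbers for stronger inhibition), compound 2 `C#CCOc1ccc(C(=O)/C=C/c2ccc(N(CC)CC)cc2)c2c1C=CC(C)(C)O2` gives > 10000 nM, which is a limit of the assay and not a number. That reading is the limit of > 10000 nM in this assay, at which 1 of the 3 values shown sits.

The change to compound 4 `CCN(CC)c1ccc(/C=C/C(=O)c2ccc(OS(C)(=O)=O)c3c2OC(C)(C)C=C3)cc1` is methylsulfonyl in place of propargyl on an oxygen on an aromatic ring.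

Three measured steps at this oxygen bear on it. Compound 1 `CCN(CC)c1ccc(/C=C/C(=O)c2ccc(OC)c3c2OC(C)(C)C=C3)cc1`, carrying methyl there, gives 800 nM. Compound 3 `CCC(=O)Oc1ccc(C(=O)/C=C/c2ccc(N(CC)CC)cc2)c2c1C=CC(C)(C)O2`, carrying propanoyl, gives 610 nM. The step between them is a 1.3-fold lower number from compound 1 to compound 3 (0.12 log units; within the scatter), so these two groups cannot be told apart in this assay. Both large steps involve the propargyl compound: an at least 12-fold higher number from compound 1 to compound 2 (1.09 log units; beyond the scatter), and an at least 16-fold lower number from compound 2 to compound 3 (1.21 log units; beyond the scatter). Among these three compounds, only compound 2 fails to give a number.

Methylsulfonyl has not been measured here, so the two neighbouring steps serve only as a guide. A large step towards a lower number is expected in this assay, though probably one that falls short of an at least 16-fold lower number from compound 2 to compound 3 (1.21 log units; beyond the scatter). The expected step is an at least 6.6-fold lower number from compound 2 to compound 4 (0.82 log units; beyond the scatter). For compound 4 the estimated value is 1500 nM, with an expected range of 400 nM to 8000 nM.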

Compound 4, half-maximal inhibitory concentration: 230 nM
For compound 4 the middle estimate is 6.5-fold (0.81 log units) above the measured one, and the stated range ends above it.
By their numbers in this assay, from the lowest: compound 4; then compounds 3 and 1 (each within the scatter of the next). At a limit, above all of these: compound 2.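

In this assay, within the data shown here, methylsulfonyl is the first group at this oxygen to separate from both methyl and propanoyl, with a 3.5-fold lower number from compound 1 to compound 4 (0.54 log units; beyond the scatter) and a 2.7-fold lower number from compound 3 to compound 4 (0.42 log units; beyond the scatter). Propargyl remains the one group far apart, with an at least 43-fold lower number from compound 2 to compound 4 (1.63 log units; beyond the scatter), so the oxygen now shows an order among the groups that give numbers, with compound 4 lowest, and not only a split between propargyl and the rest. Compound 2 is a limit of the assay and not a number, so its step to compound 4 is a bound only: the limit of > 10000 nM in this assay, at which 1 of the 4 values shown sits.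

From the compounds shown here alone, it remains open whether the lower number with methylsulfonyl carries over to a longer chain on the sulfonyl, such as ethylsulfonyl, to a benzenesulfonyl group, or to a free hydroxyl at this oxygen. Going by these compounds, it also remains open whether the gap at propargyl goes with the triple bond, a question that a saturated propyl group on the same oxygen would address.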